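Removing one chloro from the core of compound 1

This account rests on a few compounds, and the source may have more. Where it says the series, first, only, none or still open, it means among the compounds named here.

Compound 1 `ClCc1cccc(Cn2cnc3nc(Cl)nc(Cl)c32)c1` is the reference point of this pair. In a functional assay on PC-3 cells (Homo sapiens) for cytotoxicity, read by sulforhodamine B assay, with a stated time of 48 h (on this read-out higher numbers stand for lower toxicity in this test and lower numbers for higher toxicity in this test), compound 1 gives 5370 nM, the lowest of the two numbers recorded. Among the compounds with values here, the only other measured member, compound 2 `ClCc1ccccc1Cn1cnc2c(Cl)ncnc21`, gives 53700 nM in this assay, a higher number that lies beyond the usual scatter; compound 2 differs from compound 1 in more than one place, so the two values are compared as they stand and no single step is drawn between them.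

Compound 3 `ClCc1cccc(Cn2cnc3ncnc(Cl)c32)c1` is not yet measured. Relative to compound 1 the change is hydrogen in place of chloro on an aromatic carbon. The core of compound 3 matches that of compound 2, while the benzyl part matches compound 1, so compound 3 sits in an untested corner of the series.

Because compound 2 gives 53700 nM with the same core, a step upward in this assay from compound 1 to compound 3 is expected, of moderate size but likely beyond the scatter; the estimated step is a 2.8-fold higher number from compound 1 to compound 3 (0.45 log units; beyond the scatter). Compound 3 is expected to give about 15000 nM, within a range of 5000 nM to 45000 nM.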

Compound 3, concentration lethal to 50% of the cells: 63100 nM
Beside the measured number, compound 3's estimate is 4.2-fold (0.62 log units) below it; measured number above the stated range.
By their numbers in this assay, from the lowest: compound 1; then compounds 2 and 3 (each within the scatter of the next).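

In this assay, hydrogen in place of chloro on the aromatic carbon between two ring nitrogen atoms gives a 12-fold higher number from compound 1 to compound 3 (1.07 log units; beyond the scatter), a large step and the first in this series that can be read as a single change. With the benzyl part held constant, the lower number therefore goes with the chloro at this position, a link the earlier pair could not show because its members differ in more than one place. Compound 2 at 53700 nM and compound 3 at 63100 nM lie within the scatter of each other on the shared core, and no measurement at hand bears on why removing this chloro produces the step.

Going by these compounds, only chloro and hydrogen are represented at this carbon, so it remains open whether an amine, a methoxy group or a bromo there would give a number nearer that of compound 1 or that of compound 3. All the compounds shown also carry the chloromethyl group and the other chloro on the core, leaving open what a hydroxymethyl group in place of the former, or an amine in place of the latter, would do.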